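Swapping difluoromethyl for methylamino: a loss is expected

This account rests on a few compounds, and the source may have more. Where it says the series, first, only, none or still open, it means among the compounds named here.

Of the compounds shown here, three on one shared core have been measured in an assay on T-REx-293 cells for inhibition of potassium channel subfamily T member 1 (Mus musculus), read by patch clamp; on this read-out higher numbers stand for weaker inhibition and lower numbers for stronger inhibition. Compound 1 `C[C@H](NC(=O)c1cc(C(F)(F)F)nn1C)c1nc(-c2ccnc(C3CC3)c2)no1` gives 1140 nM and compound 2 `COCc1cc(-c2noc([C@H](C)NC(=O)c3cc(C(F)(F)F)nn3C)n2)ccn1` gives 17100 nM, while compound 3 `C[C@H](NC(=O)c1cc(C(F)(F)F)nn1C)c1nc(-c2ccnc(C(F)F)c2)no1` gives 1250 nM. Compound 3 therefore stands second highest of the three numbers: the step of a 1.1-fold higher number from compound 1 to compound 3 (0.04 log units; within the scatter) lies within the scatter, whereas a 14-fold lower number from compound 2 to compound 3 (1.14 log units; beyond the scatter) is a large step.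

Compound 4 `CNc1cc(-c2noc([C@H](C)NC(=O)c3cc(C(F)(F)F)nn3C)n2)ccn1` differs from compound 3 by methylamino in place of difluoromethyl on an aromatic carbon. Among the measured compounds shown here, no measured step covers this exact exchange. The closest guide is a 15-fold higher number from compound 1 to compound 2 (1.18 log units; beyond the scatter), where a group carrying an acceptor took the place of a group without one at the same position, and the same place is involved in a 14-fold lower number from compound 2 to compound 3 (1.14 log units; beyond the scatter). Because a 15-fold higher number from compound 1 to compound 2 (1.18 log units; beyond the scatter) was large and ran toward weaker inhibition, a step in the same direction, probably beyond the scatter, is expected in this assay for compound 4. Compound 4 is accordingly estimated at 6000 nM in this assay, with a range from 1500 nM to 25000 nM. The expected step is a 4.8-fold higher number from compound 3 to compound 4 (0.68 log units; beyond the scatter).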

Compound 4, half-maximal inhibitory concentration: > 30000 nM
Compound 4 ended at the assay's limit; the forecaster's own chance of this, stated with the estimate: 15%; at least 5.0-fold (0.69 log units) between middle value and limit.
By their numbers in this assay, from the lowest: compounds 1 and 3 (each within the scatter of the next); then compound 2. At a limit, above all of these: compound 4.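

In this assay compound 4 reaches a limit, which is not a number: the limit of > 30000 nM in this assay, at which 1 of the 4 values shown sits.

The earlier compounds shown here showed one group on this aromatic carbon, the methoxymethyl of compound 2, that sent the number far up; methylamino, which brings a hydrogen-bond donor and a hydrogen-bond acceptor, is a second such group, with an at least 24-fold higher number from compound 3 to compound 4 (1.38 log units; beyond the scatter) and an at least 26-fold higher number from compound 1 to compound 4 (1.42 log units; beyond the scatter). The comparison with methoxymethyl is less firm, at an at least 1.7-fold higher number from compound 2 to compound 4 (0.24 log units; that floor lies within the scatter), so how far these two groups differ stays unresolved.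

The compounds shown leave open whether the hydrogen on the methylamino nitrogen matters, which dimethylamino at this position would test. They also leave open whether a plain ethyl group would stay with cyclopropyl and difluoromethyl.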